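Side-chain extension on the amino-acid ester of compound 1

The source may hold more compounds than are shown below. What is called first, only, known or untested is meant among the compounds shown, and "the series" means these compounds.

Compound 1 `C[C@H](NC(=O)CN(c1nc(Cl)nc2[nH]cnc12)C1CC1)C(=O)OCc1ccccc1` — 44.2%
Compound 2 `O=C(CN(c1ncnc2c1ncn2C1CCCCO1)C1CC1)N[C@@H](CC(=O)OCc1ccccc1)C(=O)OCc1ccccc1` — 25.1%

Both values come from a functional assay on the whole organism (Tail, strain ICR) with Mus musculus as the target, in the tail flick test, with a stated time of 90 min, at a dose of 25 umol/kg by the oral route; a lower number here means a weaker effect, a higher number a stronger effect of the compound at the dose given. Compound 1 stands highest of the two measured compounds; compound 2 lies below it by a gap beyond the usual scatter. Among the compounds with values here, no step between measured compounds that differ in one place is available, so the series gives no direct guide for the next change. Compound 3 `CC(C)C[C@H](NC(=O)CN(c1nc(Cl)nc2[nH]cnc12)C1CC1)C(=O)OCc1ccccc1` differs from compound 1 by isopropyl in place of hydrogen on a saturated chain carbon, two bonds along the chain from an amide-type nitrogen and a carbonyl carbon. Within the data shown here, with no measured step to lean on, only a small change, of either sign or none beyond the scatter, is expected here. The expected step is a number 0.8 percentage points higher from compound 1 to compound 3 (within the scatter). For compound 3 the estimate is 45%, with a range from 25% to 65%.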

Compound 3, a percentage reported as activity, at one dose (the size of the read-out at that dose, not a potency): 15.2%
Compound 3: the middle estimate sits 29.8 percentage points above what was measured; the whole stated range lies above it.
By their numbers in this assay, from the lowest: compounds 3 and 2 (each within the scatter of the next); then compound 1.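

At the saturated chain carbon, two bonds along the chain from an amide-type nitrogen and a carbonyl carbon, isopropyl in place of hydrogen gives a step of a number 29 percentage points lower from compound 1 to compound 3 (beyond the scatter) in this assay at the dose given. This first one-place step shows that the read-out is sensitive to this position, and that going from methyl to isobutyl here lowers the effect. Nothing available bears on the reason for this drop. As far as these compounds go, whether an ethyl chain, a carboxylic acid or an amine at this position would retain the effect of compound 1 remains open.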